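Swapping Methoxyphenyl for a Fused Heteroaromatic Group

The source may hold more compounds than are shown below. What is called first, only, known or untested is meant among the compounds shown, and "the series" means these compounds.

Compound 1, `CNC(=O)c1cc(C(=O)NC2CC2)cn(Cc2ccc(OC)cc2)c1=O`: >= 143 ug/mL
Compound 2, `CNC(=O)c1cc(C(=O)NCC(C)C)cn(Cc2ccccc2)c1=O`: 43 ug/mL

Both compounds were measured in a physicochemical assay for solubility; a higher number here means a more soluble compound, a lower number a less soluble compound. For compound 1 the reported figure >= 143 ug/mL is a limit of the assay, not a number, (the limit of >= 143 ug/mL in this assay, at which 1 of the 2 values shown sits). Compound 2 gives 43 ug/mL in this assay. Compound 3 `CNC(=O)c1cc(C(=O)NC2CC2)cn(Cc2nccc3[nH]ccc23)c1=O` differs from compound 1 by a group of 9 heavy atoms (7 carbon, 2 nitrogen; one five-membered aromatic ring with 1 hetero atom, one six-membered aromatic ring with 1 hetero atom) in place of a group of 8 heavy atoms (7 carbon, 1 oxygen; one six-membered aromatic ring of carbon only), on a saturated chain carbon bound to an aromatic nitrogen. Within the data shown here, no measured pair covers this change, and compound 1 itself sits at a limit, so in this assay the expected step is small, with no move beyond the scatter in either direction. Compound 3 is expected at 150 ug/mL, between 60 ug/mL and 400 ug/mL, an expected step that the limit leaves unreadable from compound 1 to compound 3.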

Compound 3, solubility: 73 ug/mL
Estimate against measurement, compound 3: 2.1-fold (0.31 log units) above; measured number inside the range.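

In this assay, the group with a five-membered and a six-membered aromatic ring, placed on a saturated chain carbon bound to an aromatic nitrogen in place of 4-methoxyphenyl, gives an at least 1.9-fold lower number from compound 1 to compound 3 (0.29 log units; that floor lies within the scatter). The figure for compound 1 is a limit and not a number, so the full size of this step cannot be read: the limit of >= 143 ug/mL in this assay, at which 1 of the 3 values shown sits.

Unlike compound 1, compound 3 gives an actual number, 73 ug/mL.

As far as these compounds go, what a pyridine or a carboxylic acid at the same place would give remains open. So does whether the hydrogen-bond donor that enters has any part in the step.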